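A ring swap on a poorly retained compound

The source may report more compounds than this note shows. Statements on the series, on what has been measured and on what is new or still open speak of the compounds shown alone.

In an ADME assay on microsomes from liver (Rattus norvegicus) for metabolic stability, read by LC-MS, with a stated time of 1 h, at 37 degrees C, tested at 4 uM (on this read-out higher numbers stand for a more stable compound and lower numbers for a less stable compound), compound 2 (`O=C(O)c1cc(-c2cccc(COc3ccc4c(c3)CN(C3CCCC3)C4=O)c2)ccc1O`) gives 9% and sits lowest of the three numbers. Compound 1 (`O=C(O)c1cc(-c2cccc(COc3ccc4c(=O)n(CC5CC5)sc4c3)c2)ccc1Cl`) gives 75% and compound 3 (`O=C(O)c1cc(-c2cccc(COc3ccc4c(=O)n(C5CCC5)sc4c3)c2)ccc1Cl`) gives 67% but both differ from compound 2 in more than one place. Compound 4 (`Cc1ccc(C(=O)O)cc1-c1cccc(COc2ccc3c(c2)CN(C2CCCC2)C3=O)c1`) keeps the core of compound 2, with 5-carboxy-2-methylphenyl in place of 3-carboxy-4-hydroxyphenyl on an aromatic carbon. Among the measured compounds shown here, the one measured step (a number 8 percentage points lower from compound 1 to compound 3 (within the scatter)) lies within the scatter and concerns a group on an aromatic nitrogen, so it offers little guidance here. For the measured compounds named here, no measured step covers this swap, so no change beyond the scatter is expected (a number 5 percentage points higher from compound 2 to compound 4 (within the scatter)). For compound 4 the estimated value is 14% (range 4% to 35%).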

Compound 4, percent of the compound remaining: 2%
The estimate for compound 4 lay 12 percentage points above the measured number; the whole stated range lies above it.
By their numbers in this assay, from the lowest: compounds 4 and 2 (each within the scatter of the next); then compounds 3 and 1 (each within the scatter of the next).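

Among the compounds shown here, this is the first measured change at this position, and swapping in 5-carboxy-2-methylphenyl for 3-carboxy-4-hydroxyphenyl on an aromatic carbon gives, in this assay, a number 7 percentage points lower from compound 2 to compound 4 (within the scatter). On this core, the two groups therefore cannot be told apart, and neither lifts the compound out of the low numbers. Nothing available explains the poor retention of either compound. From the compounds shown here alone, it remains open whether a methoxy group on this ring, or an amide replacing the carboxylic acid, would change the number beyond the scatter.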